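This account rests on a few compounds, and the source may have more. Where it says the series, first, only, none or still open, it means among the compounds named here.

Compound 2 `Cc1ccc(S(=O)(=O)NC(=O)Nc2ccccc2C(=O)/C=C/c2cccc(Br)c2)cc1` gives the lowest of the two numbers recorded so far in an ADME assay on the whole organism for cytotoxicity, with Artemia salina as the target, with a stated time of 24 h (a higher number here means that more compound is needed for the effect, a lower number that less compound is needed), at 4.02 ug/mL. Within the data shown here, its nearest neighbour is compound 1 `CCOc1cc(/C=C/C(=O)c2ccccc2NC(=O)NS(=O)(=O)c2ccc(C)cc2)ccc1O`, which in this assay gives 19.2 ug/mL, and the one measured step, a 4.8-fold lower number from compound 1 to compound 2 (0.68 log units; beyond the scatter), came with a change on the same chain position as the one now in question.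

Compound 3 `Cc1ccc(S(=O)(=O)NC(=O)Nc2ccccc2C(=O)/C=C/C=C/c2ccccc2)cc1` differs from compound 2 in one place: 2-phenylethenyl in place of 3-bromophenyl on a double-bonded chain carbon bound to a double-bonded chain carbon. Among the measured compounds shown here, only the step from compound 1 to compound 2 bears on it, and that step exchanged one aromatic group for another at the same place, whereas here a further double-bonded link is inserted and the bromine leaves. For the measured compounds named here, no recorded step covers that kind of change, so the direction is uncertain and a modest step at most is expected, a 1.6-fold higher number from compound 2 to compound 3 (0.21 log units; within the scatter). For compound 3 the number in this assay is estimated at 6.5 ug/mL, with a range from 2.5 ug/mL to 16 ug/mL.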

Compound 3, concentration for half-maximal effect: 18.2 ug/mL
Compound 3: the middle estimate sits 2.8-fold (0.45 log units) below what was measured, and the stated range ends below it.
By their numbers in this assay, from the lowest: compound 2; then compounds 3 and 1 (each within the scatter of the next).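

On a double-bonded chain carbon bound to a double-bonded chain carbon, exchanging 3-bromophenyl for 2-phenylethenyl in this assay gives a 4.5-fold higher number from compound 2 to compound 3 (0.66 log units; beyond the scatter) and so shows that this place also responds to a change that adds a double bond outside the ring and removes the bromine. The other new step, a 1.1-fold lower number from compound 1 to compound 3 (0.02 log units; within the scatter), shows that 2-phenylethenyl and 3-ethoxy-4-hydroxyphenyl cannot be told apart here, which leaves compound 2, with its 3-bromophenyl, alone at the low end of these three compounds. Nothing available gives a reason for this gap.

The compounds shown do not separate the loss of the bromine from the added double bond, as both occur in the same step. Open too, as far as these compounds go, is how a plain phenyl or a 3-chlorophenyl at this place would compare with 3-bromophenyl.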